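This account rests on a few compounds, and the source may have more. Where it says the series, first, only, none or still open, it means among the compounds named here.

Measured so far in an assay on HEK293 cells for inhibition of diacylglycerol lipase-alpha (Homo sapiens), read by colorimetric assay, with stated times of 30 min, 60 s and 20 min; on this read-out higher numbers stand for weaker inhibition and lower numbers for stronger inhibition:
compound 1 `O=C(N1CCC=C[C@@H]1Cc1ccccc1)n1cc(-c2ccc(-c3ccccc3)cc2)nn1` — 0.794 nM
compound 2 `O=C(N1CCC=C[C@H]1Cc1ccccc1)n1cc(-c2ccc(-c3ccccc3)cc2)nn1` — 79.4 nM
compound 3 `O=C(N1CCC=C[C@@H]1COCc1ccccc1)n1cc(-c2ccc(-c3ccccc3)cc2)nn1` — 25.1 nM

Compound 3 gives the second highest number of the three; its nearest neighbour is compound 2, the furthest compound 1. The step to compound 4 `O=C(N1CCC=C[C@H]1COCc1ccccc1)n1cc(-c2ccc(-c3ccccc3)cc2)nn1` is purely configurational: the two compounds have the same atoms and bonds and differ only in configuration as drawn: 1 of 1 stereo elements differ; a stereocentre at a saturated ring carbon is drawn R in compound 3 and S in compound 4. Among the compounds with values here, the only measured step of the same kind is the inversion at the same ring carbon in the benzyl pair, a 100-fold higher number from compound 1 to compound 2 (2.00 log units; beyond the scatter), a large effect resting on (the fact that compounds 1 and 2 differ only in the configuration as drawn). Between compound 1 and compound 3 the letter of the descriptor changes, while the drawn spatial arrangement of the two is the same. Compound 4 then corresponds spatially to compound 2, the weaker epimer. A large rise in this assay is expected for compound 4, somewhat tempered since the benzyloxy series already sits higher, as the step from compound 1 to compound 3 shows (a 32-fold higher number from compound 1 to compound 3 (1.50 log units; beyond the scatter)). The expected step is a 32-fold higher number from compound 3 to compound 4 (1.50 log units; beyond the scatter). Compound 4 is estimated at 800 nM, range 200 nM to 4000 nM.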

Compound 4, half-maximal inhibitory concentration: 1260 nM
Beside the measured number, compound 4's estimate is 1.6-fold (0.20 log units) below it; the range from low to high includes it.
By their numbers in this assay, from the lowest: compound 1; then compound 3; then compound 2; then compound 4.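

In this assay, inversion at the saturated ring carbon now has a large effect with two different side chains: a 100-fold higher number from compound 1 to compound 2 (2.00 log units; beyond the scatter), and a 50-fold higher number from compound 3 to compound 4 (1.70 log units; beyond the scatter). In both pairs, the same spatial arrangement gives the higher number, so the preference at this position is not confined to the pair with the shorter side chain. Benzyloxy in place of phenyl can now also be read on the other configuration, a 16-fold higher number from compound 2 to compound 4 (1.20 log units; beyond the scatter), and the size of this change agrees on both: the same change on two cores in this assay, a 32-fold higher number (1.50 log units; beyond the scatter) from compound 1 to compound 3 and a 16-fold higher number (1.20 log units; beyond the scatter) from compound 2 to compound 4, 2.0-fold (0.30 log units) apart, within the scatter of two such steps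

On these data alone, it remains open whether the rise with benzyloxy belongs to the ether oxygen or to the longer chain; a phenylpropyl chain on the same ring carbon would separate the two. Equally open, as far as these compounds go, is how an amine or a carboxylic acid in that side chain would read.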